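A few compounds are considered here, and "the series" means these few. Any claim that something is new, unique, unknown or untested is made for them only; others in the source may bear on it.

Compound 1 `CN(c1ccc2[nH]c(-c3n[nH]c4ccccc34)cc2n1)S(=O)(=O)c1ccccc1` gives 3700 nM in a functional assay on HL-60 cells (Homo sapiens) for antiproliferative activity, read by MTT assay, with a stated time of 72 h; on this read-out lower numbers stand for stronger inhibition and higher numbers for weaker inhibition.
Compound 2 `CN(c1ccc2[nH]c(-c3n[nH]c4ccccc34)cc2n1)S(=O)(=O)c1ccc(Cl)cc1` gives 770 nM.
Compound 3 `CN(c1ccc2[nH]c(-c3n[nH]c4ccccc34)cc2n1)S(=O)(=O)c1ccc(Br)cc1` gives 6240 nM.

Compound 3 stands at the highest number of the three: its gap to compound 1 is within the scatter (a 1.7-fold higher number from compound 1 to compound 3 (0.23 log units; within the scatter)), while its gap to compound 2 is beyond it (an 8.1-fold higher number from compound 2 to compound 3 (0.91 log units; beyond the scatter)). Compound 4 `COc1ccc(S(=O)(=O)N(C)c2ccc3[nH]c(-c4n[nH]c5ccccc45)cc3n2)cc1` differs from compound 3 by methoxy in place of bromo on an aromatic carbon. Among the measured compounds shown here, no measured step exchanges a halogen for methoxy here, so only the halogen steps bear on it: a 4.8-fold lower number from compound 1 to compound 2 (0.68 log units; beyond the scatter) and an 8.1-fold higher number from compound 2 to compound 3 (0.91 log units; beyond the scatter), both modest and in opposite directions. A modest step to a lower number is therefore expected for compound 4, a 2.5-fold lower number from compound 3 to compound 4 (0.40 log units; beyond the scatter). For compound 4 the estimate in this assay is 2500 nM, with a range of 600 nM to 10000 nM.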

Compound 4, half-maximal inhibitory concentration: 4340 nM
Estimate against measurement, compound 4: 1.7-fold (0.24 log units) below; the range from low to high includes it.
By their numbers in this assay, from the lowest: compound 2; then compounds 1, 4 and 3 (each within the scatter of the next).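

Methoxy at this position gives no separation from hydrogen (a 1.2-fold higher number from compound 1 to compound 4 (0.07 log units; within the scatter)) or from bromo (a 1.4-fold lower number from compound 3 to compound 4 (0.16 log units; within the scatter)). The gain seen with chloro does not extend to methoxy (a 5.6-fold higher number from compound 2 to compound 4 (0.75 log units; beyond the scatter)), so compound 2 stands alone in this assay, with compounds 1, 3 and 4 forming one level. No evidence on hand bears on this result.

On these data alone, whether the chloro result is specific to that atom remains open. Fluoro, an amine or a carboxylic acid on this carbon could test how narrow it is.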